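A trifluoromethyl step from compound 2

The source may hold more compounds than are shown below. What is called first, only, known or untested is meant among the compounds shown, and "the series" means these compounds.

In a functional assay on A549 cells (Homo sapiens) for antiproliferative activity, read by sulforhodamine B assay, with a stated time of 48 h (a lower number here means a stronger inhibitor of growth, a higher number a weaker inhibitor of growth), compound 2 (`Cc1cc2c(cc1C)C(Cl)=C(c1nnc(-c3ccccc3)o1)CCC2`) gives 1960 nM, at the low end of the three numbers. Compound 3 (`Cc1cc2c(cc1C)C(Cl)=C(c1nnc(-c3ccc(F)cc3)o1)CCC2`) gives 2810 nM, within the scatter of compound 2. Compound 1 (`O=C(NNC(=S)Nc1ccccc1)C1=C(Cl)c2ccccc2CCC1`) gives 4880 nM, beyond the scatter from compound 2. Compound 4 (`Cc1cc2c(cc1C)C(Cl)=C(c1nnc(-c3cccc(C(F)(F)F)c3)o1)CCC2`) is not yet measured and changes compound 2 by trifluoromethyl in place of hydrogen on an aromatic carbon, meta to a large group. Among the compounds with values here, the only measured step that bears on this is fluoro in place of hydrogen on an aromatic carbon, a 1.4-fold higher number from compound 2 to compound 3 (0.16 log units; within the scatter), and it involves a different group. The expected step is therefore a 1.3-fold higher number from compound 2 to compound 4 (0.11 log units; within the scatter), not beyond the scatter. The estimate for compound 4 is 2500 nM, with an expected range of 1000 nM to 6000 nM.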

Compound 4, concentration for 50% growth inhibition: 1970 nM
Estimate against measurement, compound 4: 1.3-fold (0.10 log units) above; low and high end bracket the measured number.
By their numbers in this assay, from the lowest: compounds 2, 4, 3 and 1 (each within the scatter of the next, the first and the last beyond it).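

In this assay, trifluoromethyl in place of hydrogen, meta to a large group, gives a 1.0-fold higher number from compound 2 to compound 4 (0.00 log units; within the scatter), so a group of four heavy atoms on this aromatic carbon leaves the number within the scatter. The earlier compounds shown here showed only the fluoro step, a 1.4-fold higher number from compound 2 to compound 3 (0.16 log units; within the scatter), and so did not show that this larger group is accepted here. No measurement shown here explains this result.

The compounds shown leave open whether an amine or a carboxylic acid on this carbon would also stay within the scatter. They also leave open whether trifluoromethyl would give a similar step on the other carbons of this ring.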